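Two Halogens Added to the Outer Phenyl Ring

This account rests on a few compounds, and the source may have more. Where it says the series, first, only, none or still open, it means among the compounds named here.

Of the compounds shown here, three built on one shared core have been tested in a functional assay on A549 cells (Homo sapiens) for cytotoxicity, read by MTT assay, with a stated time of 72 h; on this read-out higher numbers stand for weaker inhibition and lower numbers for stronger inhibition. Compound 1 `COc1cc2c(Oc3ccc(NC(=O)N/N=C/c4ccncc4)cc3F)ccnc2cc1OCCCN1CCCCC1` gives 840 nM, compound 2 `COc1cc2c(Oc3ccc(NC(=O)N/N=C/c4cccs4)cc3F)ccnc2cc1OCCCN1CCCCC1` gives 790 nM, and compound 3 `COc1cc2c(Oc3ccc(/C=N/NC(=O)Nc4ccccc4)cc3F)ccnc2cc1OCCCN1CCCCC1` gives 280 nM, the lowest number of the three; the steps of a 3.0-fold lower number from compound 1 to compound 3 (0.48 log units; beyond the scatter) and a 2.8-fold lower number from compound 2 to compound 3 (0.45 log units; beyond the scatter) both lie beyond the scatter, whereas a 1.1-fold lower number from compound 1 to compound 2 (0.03 log units; within the scatter) does not. Compound 4 `COc1cc2c(Oc3ccc(/C=N/NC(=O)Nc4ccc(F)cc4Br)cc3F)ccnc2cc1OCCCN1CCCCC1` differs from compound 3 only in 2-bromo-4-fluorophenyl in place of phenyl on an amide-type nitrogen. For the measured compounds named here, none of the measured steps alters that outer phenyl, so no direct guide exists for this change; the rest of the molecule is untouched, and a step of at most modest size, in either direction, is expected. Compound 4 is therefore expected to give about 200 nM, within 70 nM to 600 nM, corresponding to an estimated step of a 1.4-fold lower number from compound 3 to compound 4 (0.15 log units; within the scatter).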

Compound 4, half-maximal inhibitory concentration: 98 nM
Compound 4: middle estimate off by 2.0-fold (0.31 log units), on the high side, within the range that was stated.
By their numbers in this assay, from the lowest: compound 4; then compound 3; then compounds 2 and 1 (each within the scatter of the next).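

For the compounds shown here, the outer phenyl on the amide-type nitrogen proves sensitive to substitution: in this assay, 2-bromo-4-fluorophenyl in place of phenyl gives a 2.9-fold lower number from compound 3 to compound 4 (0.46 log units; beyond the scatter), whereas no earlier step changed this ring. Adding the two halogens to this ring therefore lowers the number rather than raising it. Nothing available explains this gain.

Since bromine and fluorine enter together, the compounds shown cannot separate what each contributes. They also leave open how a methoxy group or a dimethylamino group on this ring would behave.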